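This account rests on a few compounds, and the source may have more. Where it says the series, first, only, none or still open, it means among the compounds named here.

- Compound 1 `O=C1CCC[C@@H]([C@H]2C[C@@H]2c2ccccc2)O1`: > 100000 nM (a limit)
- Compound 2 `O=C1C=CC[C@H]([C@H]2C[C@@H]2c2ccccc2)O1`: 11600 nM
- Compound 3 `O=C1C=CC[C@@H](/C=C/C2CCCCC2)O1`: 68600 nM

In a functional assay on A549 cells (Homo sapiens) for antiproliferative activity, read by luminescence and CellTiter-Glo, with a stated time of 48 h (a lower number here means a stronger inhibitor, a higher number a weaker inhibitor), compound 1 is known only by a limit and not by a number: it stands at the limit of > 100000 nM in this assay, at which 1 of the 3 values shown sits. Compound 4 `O=C1CCC[C@H]([C@@H]2C[C@H]2c2ccccc2)O1` is related to compound 1 as follows: the two compounds have the same atoms and bonds and differ only in configuration as drawn: 3 of 3 stereo elements differ (all stereocentres are inverted: mirror images); a stereocentre at a saturated ring carbon is drawn S in compound 1 and R in compound 4; a stereocentre at a saturated ring carbon is drawn S in compound 1 and R in compound 4; a stereocentre at a saturated ring carbon is drawn S in compound 1 and R in compound 4. Going by the values given here, no measured pair here tests such an inversion, so the data give no direct guide to its size. Only a small move towards a lower number is expected, and compound 4 may also end up reported as a limit. The expected step is an at least 1.2-fold lower number from compound 1 to compound 4 (0.09 log units; that floor lies within the scatter). Compound 4 is estimated at 80000 nM, with an expected range of 25000 nM to 150000 nM.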

Compound 4, half-maximal inhibitory concentration: > 100000 nM
Compound 4 was reported as a limit; the forecaster's own chance of this, stated with the estimate: 55%; middle value at least 1.2-fold (0.09 log units) from the limit.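

Going by these compounds alone, compound 1 and compound 4 are both reported only as limits in this assay, so no step between them can be read. The compounds shown leave open whether these two mirror images differ at all.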